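Piperazin-1-yl to (2-Hydroxyethyl)amino on a Shared Core

A few compounds are considered here, and "the series" means these few. Any claim that something is new, unique, unknown or untested is made for them only; others in the source may bear on it.

Of the compounds shown here, three have been tested in an assay on HEK293 cells for displacement of a labelled ligand from NPC1-like intracellular cholesterol transporter 1 (Homo sapiens); a lower number here means a stronger inhibitor, a higher number a weaker inhibitor. Compound 1 `CC(C)(C)OC(=O)NCC1CCCN(C(=O)CN2CN(c3ccccc3)C3(CCN(C(=O)c4ccc(C5CCCCC5)cc4)CC3)C2=O)C1` gives 3800 nM, compound 2 `O=C(CN1CN(c2ccccc2)C2(CCN(C(=O)c3ccc(C4CCCCC4)cc3)CC2)C1=O)NCCCCO` gives 10300 nM, and compound 3 `CC(C)(C)c1ccc(C(=O)N2CCC3(CC2)C(=O)N(CC(=O)N2CCNCC2)CN3c2ccccc2)cc1` gives 22000 nM. Compound 3 therefore stands at the highest number of the three, beyond the scatter from compound 2 and further still from compound 1. Compound 4 `CC(C)(C)c1ccc(C(=O)N2CCC3(CC2)C(=O)N(CC(=O)NCCO)CN3c2ccccc2)cc1` differs from compound 3 in one place: (2-hydroxyethyl)amino in place of piperazin-1-yl on a carbonyl carbon. Among the compounds with values here, no measured pair shows exactly this change, so any expectation rests on the neighbours. Compound 2, whose tail is also an open chain carrying a hydroxyl and which gives 10300 nM, suggests such a tail is tolerated. Compound 4 is therefore expected to give 12000 nM, within 4000 nM to 35000 nM. The step of a 1.8-fold lower number from compound 3 to compound 4 (0.26 log units; within the scatter) is expected to be a modest decrease in number, close to the scatter.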

Compound 4, half-maximal inhibitory concentration: 1000 nM
For compound 4 the middle estimate is 12-fold (1.08 log units) above the measured one, outside the stated range (below it).
By their numbers in this assay, from the lowest: compound 4; then compound 1; then compound 2; then compound 3.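

In this assay, putting the open (2-hydroxyethyl)amino chain on this carbonyl carbon in place of the piperazin-1-yl ring gives a 22-fold lower number from compound 3 to compound 4 (1.34 log units; beyond the scatter), a large step. This position is therefore not indifferent: on this shared core, the group on the carbonyl carbon can shift the number strongly, and the ring is not required for the stronger result. Nothing measured here explains the size of this step.

From the compounds shown here alone, whether the hydroxyl or the open chain matters more remains open, and a plain ethylamino group on the same carbonyl carbon would separate the two. A longer chain, (3-hydroxypropyl)amino, would show whether the hydroxyl's distance from the amide matters.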